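This account rests on a few compounds, and the source may have more. Where it says the series, first, only, none or still open, it means among the compounds named here.

Compound 1 `Nc1cccc(C#CC#Cc2cn([C@H]3C[C@H](O)[C@@H](CO)O3)c(=O)[nH]c2=O)c1`: in an ADME assay on HEL cells (Homo sapiens) for cytotoxicity, read by microscopy (a higher number here means that more compound is tolerated, a lower number that less compound is tolerated), compound 1 gives > 100000 nM, which is a limit of the assay and not a number.
Compound 2 `Nc1ccc(C#CC#Cc2cn([C@H]3C[C@H](O)[C@@H](CO)O3)c(=O)[nH]c2=O)cc1`: in this assay compound 2 gives > 100000 nM, again a limit.
Compound 3 `Cc1cc(C#CC#Cc2cn([C@H]3C[C@H](O)[C@@H](CO)O3)c(=O)[nH]c2=O)ccc1F`: in this assay compound 3 gives 100000 nM.

For the measured compounds named here, compound 3 thus stands as the only numbered value here; the other two are limits (the limit of > 100000 nM in this assay, at which 2 of the 3 values shown sit). Compound 4 `O=c1[nH]c(=O)n([C@H]2C[C@H](O)[C@@H](CO)O2)cc1C#CC#CC1CC1` differs from it by cyclopropyl in place of 4-fluoro-3-methylphenyl on a triple-bonded carbon. Going by the values given here, the measured steps that bear on this are a number no higher from compound 1 to compound 3 (the limit leaves the size open) and a number no higher from compound 2 to compound 3 (the limit leaves the size open), and a step that the two limits leave unreadable from compound 1 to compound 2 is likewise unreadable, so no step of readable size is known for any change at this position. No shift beyond the scatter is therefore expected. Compound 4 is expected to give 100000 nM, between 50000 nM and 100000 nM. The expected step is no change at the digits printed from compound 3 to compound 4 (within the scatter).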

Compound 4, minimum cytotoxic concentration: > 100000 nM
Compound 4: a limit, no number (the forecaster's own chance of this, stated with the estimate: 60%); the middle value lies on the limit itself.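

Putting cyclopropyl in place of 4-fluoro-3-methylphenyl on the triple-bonded carbon gives a number no lower from compound 3 to compound 4 (the limit leaves the size open), so in this assay a non-aromatic ring of carbon only does no worse here than the aromatic rings. The steps from compound 1 and compound 2 to compound 4 cannot be read, since both ends of each are limits. This leaves little that can be ranked at this position: the limit of > 100000 nM in this assay, at which 3 of the 4 values shown sit.

From the compounds shown here alone, whether a carboxylic acid or a longer alkyl chain on the triple-bonded carbon would lower the number remains open. So does any order among compound 1, compound 2 and compound 4.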